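This account rests on a few compounds, and the source may have more. Where it says the series, first, only, none or still open, it means among the compounds named here.

In a functional assay on the whole organism (artery, strain albino) with Rattus norvegicus as the target, with a stated time of 120 min, at a dose of 10 mg/kg by the oral route (a lower number here means less inhibition, a higher number more inhibition at the dose given (going by the name of the read-out)), the measured compounds gave these numbers:

compound 1 `COc1ccc(C2N=C(SCc3ccccc3Cl)NC(C)=C2C(=O)Nc2ccc(Br)cc2)cc1`: 8.2%
compound 2 `COc1ccc(C2N=C(SCc3cccc(Cl)c3)NC(C)=C2C(=O)Nc2ccc(Br)cc2)cc1`: 21.1%
compound 3 `CC1=C(C(=O)Nc2ccc([N+](=O)[O-])cc2)C(c2ccc(Br)cc2)N=C(SCc2ccccc2Cl)N1`: 7.7%

Compound 2 differs from compound 1 only by 3-chlorophenyl in place of 2-chlorophenyl on a saturated chain carbon bound to a sulfur, and this change produced a number 12.9 percentage points higher from compound 1 to compound 2 (beyond the scatter). Compound 3 carries a different core; how the cores of compound 1 and compound 3 differ is not broken down here, and the two give numbers within the scatter of each other. Compound 4 `CC1=C(C(=O)Nc2ccc([N+](=O)[O-])cc2)C(c2ccc(Br)cc2)N=C(SCc2cccc(Cl)c2)N1` stands to compound 3 as compound 2 stands to compound 1, the change being 3-chlorophenyl in place of 2-chlorophenyl on a saturated chain carbon bound to a sulfur at the same place. Within the data shown here, with only one earlier example of this change, the expectation for compound 4 is a step of similar size, a number 12.3 percentage points higher from compound 3 to compound 4 (beyond the scatter), because a number 12.9 percentage points higher from compound 1 to compound 2 (beyond the scatter) is the only guide available. Compound 4 is therefore estimated at 20%, most likely between 8% and 32%.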

Compound 4, a percentage reported as inhibition, in the whole organism at one dose (the size of the read-out at that dose, not a potency): 6.7%
Estimate against measurement, compound 4: 13.3 percentage points above; the measured number lies below the stated range.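

Swapping 2-chlorophenyl for 3-chlorophenyl gave a number 12.9 percentage points higher from compound 1 to compound 2 (beyond the scatter) in this assay, whereas on the core of compound 3 the same swap gave a number 1 percentage points lower from compound 3 to compound 4 (within the scatter). The rise seen on the first core thus did not appear on the second, yet the two steps cannot be told apart with confidence: the same change on two cores in this assay, a number 12.9 percentage points higher (beyond the scatter) from compound 1 to compound 2 and a number 1 percentage points lower (within the scatter) from compound 3 to compound 4, 13.9 percentage points apart, within the scatter of two such steps. With a single pair on each core, these results neither show that the swap depends on the core nor show that it carries over reliably.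

The compounds shown leave open how a plain phenyl, without chlorine, or a carboxylic acid on that ring would behave on either core. They also leave open whether a longer chain between the sulfur and the ring would change the result.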